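The compounds below may be only part of what the source reports. "The series", "measured", "known", "first", "only" and "open" are said of these compounds alone.

Series notes. Compound 1 `Nc1cccc(-c2cn3nc(CCc4ccccc4)sc3n2)c1` gives 30000 nM in a functional assay on CCRF-CEM cells (Homo sapiens) for inhibition, read by cell counting, with a stated time of 3 days; on this read-out lower numbers stand for stronger inhibition and higher numbers for weaker inhibition. Compound 2 `COc1ccc(Cc2nn3cc(-c4cccc(N)c4)nc3s2)cc1` reaches only a limit of this assay, >= 250000 nM, as recorded in the limit of >= 250000 nM in this assay, at which 1 of the 2 values shown sits. Among the compounds with values here, the sole measured step, an at least 8.3-fold higher number from compound 1 to compound 2 (0.92 log units; beyond the scatter), is the only guide to the series. Compound 3 `COc1cccc(Cc2nn3cc(-c4cccc(N)c4)nc3s2)c1` differs from compound 2 by 3-methoxyphenyl in place of 4-methoxyphenyl on a saturated chain carbon bound to an aromatic carbon. Both keep a methoxyphenyl on a saturated chain carbon bound to an aromatic carbon, and nothing measured separates the two methoxy positions, so for compound 3 a number near the limit is expected, 200000 nM, within 60000 nM to 300000 nM, with an at least 1.2-fold lower number from compound 2 to compound 3 (0.09 log units; that floor lies within the scatter) as the expected step.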

Compound 3, half-maximal inhibitory concentration: 40000 nM
Compound 3: middle estimate off by 5.0-fold (0.70 log units), on the high side; measured number outside the range, below it.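

Moving the methoxy group matters at this place, on a saturated chain carbon bound to an aromatic carbon: in this assay, 3-methoxyphenyl in place of 4-methoxyphenyl gives an at least 6.2-fold lower number from compound 2 to compound 3 (0.79 log units; beyond the scatter). 3-Methoxyphenyl in place of benzyl gives a 1.3-fold higher number from compound 1 to compound 3 (0.12 log units; within the scatter), so the two are not told apart and the poor result of 4-methoxyphenyl does not carry over to 3-methoxyphenyl. Compound 2 stands at a limit, so the first step is only a floor: the limit of >= 250000 nM in this assay, at which 1 of the 3 values shown sits.

Open, from the compounds shown here alone, is whether 3-hydroxyphenyl or 3-chlorophenyl at this place would match 3-methoxyphenyl. Also open, going by these compounds, is whether any group here gives a much lower number than these compounds do.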